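Amide to sulfonamide on a shared core

The source may hold more compounds than are shown below. What is called first, only, known or untested is meant among the compounds shown, and "the series" means these compounds.

Measured so far:
compound 1 `O=C(Nc1cccc(/C=C/C(=O)c2nc3ccccc3[nH]2)c1)c1cccc(C(F)(F)F)c1`: 9570 nM
compound 2 `COc1cccc(C(=O)Nc2cccc(/C=C/C(=O)c3nc4ccccc4[nH]3)c2)c1`: 4610 nM

Both compounds were tested in a functional assay on 143B cells (Homo sapiens) for antiproliferative activity, read by MTT assay, with a stated time of 48 h; on this read-out lower numbers stand for stronger inhibition and higher numbers for weaker inhibition. Compound 2 gives the lowest of the two numbers; its nearest neighbour, compound 1, sits a 2.1-fold lower number from compound 1 to compound 2 (0.32 log units; beyond the scatter) away, a modest gap that still lies beyond the scatter.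

Compound 3 `Cc1cccc(S(=O)(=O)Nc2cccc(/C=C/C(=O)c3nc4ccccc4[nH]3)c2)c1` is not yet measured. It differs from compound 2 in one place: (3-methylphenyl)sulfonyl in place of (3-methoxyphenyl)carbonyl on a nitrogen on an aromatic ring. Within the data shown here, no measured step touches this change. Among the measured compounds shown here, the only step known, the exchange of one group for another on the aromatic carbon, is a 2.1-fold lower number from compound 1 to compound 2 (0.32 log units; beyond the scatter) and does not involve the nitrogen or the carbonyl. With nothing to lean on, the expectation for compound 3 is a number close to that of compound 2, with a step of about a 1.1-fold higher number from compound 2 to compound 3 (0.04 log units; within the scatter) that is expected to stay within the scatter. Compound 3 is therefore estimated at 5000 nM, with a range from 1500 nM to 16000 nM.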

Compound 3, half-maximal inhibitory concentration: 791 nM
For compound 3 the middle estimate is 6.3-fold (0.80 log units) above the measured one; the measured number lies below the stated range.
By their numbers in this assay, from the lowest: compound 3; then compound 2; then compound 1.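

In this assay the group on a nitrogen on an aromatic ring proves to matter: (3-methylphenyl)sulfonyl in place of (3-methoxyphenyl)carbonyl gives a 5.8-fold lower number from compound 2 to compound 3 (0.77 log units; beyond the scatter) on the shared core. The earlier compounds shown here showed only a change on an aromatic carbon, a 2.1-fold lower number from compound 1 to compound 2 (0.32 log units; beyond the scatter), and said nothing about this nitrogen. The two groups that trade places have equal counts of heavy atoms, hydrogen-bond donors and hydrogen-bond acceptors, and no measurement here explains the shift.

This single step changes the carbonyl to a sulfonyl and the methoxy to a methyl at once, and the compounds shown cannot say which of the two carries it. A (3-methoxyphenyl)sulfonyl or a (3-methylphenyl)carbonyl group on the same nitrogen would pull the two changes apart.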